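Working notes: methoxy removal in the sulfonyl indole series

A few compounds are considered here, and "the series" means these few. Any claim that something is new, unique, unknown or untested is made for them only; others in the source may bear on it.

Measured so far:
compound 1, `CC(=O)/C(=C\c1c(-c2ccccc2)[nH]c2ccccc12)S(=O)(=O)c1ccccc1`: 3400 nM in a functional assay on SF-268 cells (Homo sapiens) for inhibition, read by sulforhodamine B assay, with a stated time of 48 h; on this read-out lower numbers stand for stronger inhibition of growth and higher numbers for weaker inhibition of growth
compound 2, `COc1ccc2[nH]c(-c3ccccc3)c(/C=C(\C#N)S(=O)(=O)c3ccccc3)c2c1`: 13300 nM in this assay

Compound 2 stands at the higher of the two numbers in this assay; compound 1 lies below it by a margin beyond the scatter. Among the compounds with values here, no pair of measured compounds differing in a single place is available, so no single change has an observed step. Compound 3, `N#C/C(=C\c1c(-c2ccccc2)[nH]c2ccccc12)S(=O)(=O)c1ccccc1`, differs from compound 2 by hydrogen in place of methoxy on an aromatic carbon. A small move toward a lower number is expected, possibly within the scatter. Compound 3 is estimated at 7000 nM in this assay, range 2500 nM to 20000 nM. This amounts to an expected 1.9-fold lower number from compound 2 to compound 3 (0.28 log units; within the scatter).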

Compound 3, concentration for 50% growth inhibition: 4500 nM
Compound 3: middle estimate off by 1.6-fold (0.19 log units), on the high side, and the stated range covers the measured number.
By their numbers in this assay, from the lowest: compounds 1 and 3 (each within the scatter of the next); then compound 2.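

Hydrogen in place of methoxy on this aromatic carbon gives the first single-change reading in the series: in this assay, the step is (a 3.0-fold lower number from compound 2 to compound 3 (0.47 log units; beyond the scatter)), so methoxy at this place is not favoured against hydrogen when cyano is present. Cyano in place of acetyl gives (a 1.3-fold higher number from compound 1 to compound 3 (0.12 log units; within the scatter)), so the two groups are not distinguished on the methoxy-free core.

As far as these compounds go, whether an amine or a hydroxyl group at this aromatic carbon would behave like hydrogen or like methoxy remains open, as does the methoxy step alongside acetyl. No available evidence accounts for either step.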